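Trifluoromethyl in place of methyl in compound 2

The source may report more compounds than this note shows. Statements on the series, on what has been measured and on what is new or still open speak of the compounds shown alone.

Measured in a functional assay on CWR22R cells (Homo sapiens) for antiproliferative activity, with a stated time of 96 h (a higher number here means a weaker inhibitor, a lower number a stronger inhibitor), so far:
- compound 1 `Cc1cc(=O)oc2cc(OCC(=O)c3cc(C(F)(F)F)cc(C(F)(F)F)c3)ccc12` gives 930 nM
- compound 2 `Cc1cc(=O)oc2cc(OCC(=O)c3ccc4ccccc4c3)ccc12` gives > 100000 nM
- compound 3 `O=C(COc1ccc2c(C(F)(F)F)cc(=O)oc2c1)c1cc(C(F)(F)F)cc(C(F)(F)F)c1` gives "not active" (no number reported)

In this assay compound 2 reads > 100000 nM, which is a limit of the assay and not a number.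

Compound 4 `O=C(COc1ccc2c(C(F)(F)F)cc(=O)oc2c1)c1ccc2ccccc2c1` has not yet been measured. It differs from compound 2 in one place, with trifluoromethyl in place of methyl on an aromatic carbon, opposite the ring oxygen (trifluoromethyl in place of methyl on an aromatic carbon).

For the measured compounds named here, the only other pair with this change offers a guide. Compound 1, with methyl at that place, gives 930 nM in this assay. With trifluoromethyl there, compound 3 gives "not active" (no number reported), so compound 3 offers no reason to expect a gain.

The expected change, a number no higher from compound 2 to compound 4 (the limit leaves the size open), is no step beyond the scatter in either direction, and a report of only a limit is the likeliest result. For compound 4 the estimated half-maximal inhibitory concentration is 100000 nM, with an expected range from 20000 nM to 200000 nM.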

Compound 4, half-maximal inhibitory concentration: "not active" (no number reported)
Compound 4: no number reported; the estimate stays without a comparison.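

Compound 2 reads > 100000 nM, which is a limit of the assay and not a number. For the compounds shown here, compound 4 is reported as "not active" with no number, so no step between compound 2 and compound 4 can be read. The compounds shown leave open what effect, if any, trifluoromethyl in place of methyl has on antiproliferative activity: neither pair with this change gives two numbers.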